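Cytotoxicity unchanged by a cyano-for-trifluoromethyl swap

The source may report more compounds than this note shows. Statements on the series, on what has been measured and on what is new or still open speak of the compounds shown alone.

Measured compounds:
compound 1 `O=[N+]([O-])c1cn2c(n1)OC[C@@H](OCc1ccc(-c3ccc(C(F)(F)F)cc3)s1)C2` — > 128000 nM
compound 2 `N#Cc1ccc(-c2ccc(CO[C@@H]3COc4nc([N+](=O)[O-])cn4C3)s2)cc1` — > 128000 nM
compound 3 `O=[N+]([O-])c1cn2c(n1)OC[C@@H](OCc1cc(-c3ccc(C(F)(F)F)cc3)no1)C2` — > 128000 nM

In an ADME assay on Vero cells (Chlorocebus sabaeus) for cytotoxicity, with a stated time of 72 h (on this read-out lower numbers stand for stronger inhibition and higher numbers for weaker inhibition), compound 1 gives > 128000 nM, which is a limit of the assay and not a number. Compound 2 likewise gives > 128000 nM, again a limit. Compound 3 gives > 128000 nM, a limit as well. From compound 1 to compound 2 the change is cyano in place of trifluoromethyl on an aromatic carbon; the corresponding step, a step that the two limits leave unreadable from compound 1 to compound 2, cannot be read because both ends sit at the limit of > 128000 nM in this assay, at which 3 of the 3 values shown sit. The difference between the core of compound 1 and the core of compound 3 is not broken down here. Compound 4 `N#Cc1ccc(-c2cc(CO[C@@H]3COc4nc([N+](=O)[O-])cn4C3)on2)cc1` is related to compound 3 by the same change, (cyano in place of trifluoromethyl on an aromatic carbon), on an identical place. Because every measured value sits at the limit of > 128000 nM in this assay, at which 3 of the 3 values shown sit, the step from compound 3 to compound 4 is expected to be unreadable, a number no higher from compound 3 to compound 4 (the limit leaves the size open). Compound 4 is therefore estimated at 128000 nM in this assay, between 64000 nM and 400000 nM, most likely reported only as a limit.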

Compound 4, half-maximal inhibitory concentration: > 128000 nM
Compound 4: a limit, no number (the forecaster's own chance of this, stated with the estimate: 85%); the middle value sits exactly at the limit.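

No step can be read from compound 3 to compound 4 in this assay because both values are limits and not numbers: the limit of > 128000 nM in this assay, at which 4 of the 4 values shown sit. The compounds shown leave open at what concentration, if any, each would inhibit these cells.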